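The source may report more compounds than this note shows. Statements on the series, on what has been measured and on what is new or still open speak of the compounds shown alone.

Measured compounds: compound 1 `COc1nc(F)nc2c1ncn2[C@H]1C[C@H](N=[N+]=[N-])[C@@H](CO)O1` with 9400 nM in an ADME assay on PBMC cells (Homo sapiens) for cytotoxicity, with a stated time of 5 days; a lower number here means a stronger inhibitor, a higher number a weaker inhibitor; compound 3 `[N-]=[N+]=N[C@H]1C[C@H](n2cnc3c(N)nc(F)nc32)O[C@@H]1CO` with 30100 nM; compound 2 `COc1nc(Cl)nc2c1ncn2[C@H]1C[C@H](N=[N+]=[N-])[C@@H](CO)O1`. For compound 2 this assay reports only a limit, > 100000 nM, the limit described in the limit of > 100000 nM in this assay, at which 1 of the 3 values shown sits.

The cores of compound 1 and compound 3 differ in one place, (amino in place of methoxy on an aromatic carbon), a change that gives a 3.2-fold higher number from compound 1 to compound 3 (0.51 log units; beyond the scatter). The change from compound 1 to compound 2 is chloro in place of fluoro on an aromatic carbon, and it gives an at least 10-fold higher number from compound 1 to compound 2 (1.02 log units; beyond the scatter). Compound 4 `[N-]=[N+]=N[C@H]1C[C@H](n2cnc3c(N)nc(Cl)nc32)O[C@@H]1CO` is not yet measured. It differs from compound 3 by chloro in place of fluoro on an aromatic carbon, the same kind of change, the place now being meta to an amino group rather than meta to a methoxy group. A step of a 5.0-fold higher number from compound 3 to compound 4 (0.70 log units; beyond the scatter) is expected, resting on an at least 10-fold higher number from compound 1 to compound 2 (1.02 log units; beyond the scatter). Compound 4 is therefore estimated at 150000 nM, between 60000 nM and 400000 nM, and may well return as a limit.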

Compound 4, half-maximal inhibitory concentration: 35800 nM
The estimate for compound 4 lay 4.2-fold (0.62 log units) above the measured number; measured number below the stated range.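

In this assay, chloro in place of fluoro with the amino group present gives a 1.2-fold higher number from compound 3 to compound 4 (0.08 log units; within the scatter), so the large step seen with the methoxy group did not carry over: the same change on two cores in this assay, an at least 10-fold higher number (1.02 log units; beyond the scatter) from compound 1 to compound 2 and a 1.2-fold higher number (0.08 log units; within the scatter) from compound 3 to compound 4, at least 8.9-fold (0.95 log units) apart, beyond the scatter of two such steps

Amino in place of methoxy also behaves differently with chloro present, giving an at least 2.7-fold lower number from compound 2 to compound 4 (0.44 log units; beyond the scatter), a step that starts from a limit reported for compound 2: the same change on two cores in this assay, a 3.2-fold higher number (0.51 log units; beyond the scatter) from compound 1 to compound 3 and an at least 2.7-fold lower number (0.44 log units; beyond the scatter) from compound 2 to compound 4, at least 8.9-fold (0.95 log units) apart, beyond the scatter of two such steps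

Neither change therefore keeps one size across these cores, but two pairs give no rule for any other core and do not show why the steps differ.

The compounds shown leave open how bromo at the same place would behave on either core. They also leave open what a methylamino group in place of amino would give.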